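A few compounds are considered here, and "the series" means these few. Any claim that something is new, unique, unknown or untested is made for them only; others in the source may bear on it.

Working notes on the series. Compound 2 `Nc1ccccc1NC(=O)c1ccc(CSC(=S)N2CCc3cc([N+](=O)[O-])ccc32)cc1` stands lowest of the two numbers measured in a functional assay on MGC-803 cells (Homo sapiens) for antiproliferative activity, read by CCK-8 assay, with a stated time of 72 h, tested at 2 uM; a higher number here means a stronger effect of the compound at the concentration tested, a lower number a weaker effect: compound 2 gives 26.8%, whereas compound 1 `Nc1ccccc1NC(=O)c1ccc(CSC(=S)N2CCc3cc(Cl)ccc32)cc1` gives 57.7%. For the measured compounds named here, the only measured step is a number 30.9 percentage points lower from compound 1 to compound 2 (beyond the scatter), a large fall. Compound 3 `COC(=O)c1ccc2c(c1)CCN2C(=S)SCc1ccc(C(=O)Nc2ccccc2N)cc1` differs from compound 2 by methoxycarbonyl in place of nitro on an aromatic carbon. Going by the values given here, the single step on record bears on this change only indirectly: it shows that exchanging the substituent at this aromatic carbon can move the number a long way, but it says nothing about methoxycarbonyl itself, and no return to the chloro of compound 1 is involved. The expectation is therefore a partial recovery, with the step of a number 13.2 percentage points higher from compound 2 to compound 3 (beyond the scatter) estimated smaller than the fall already seen. Compound 3 is estimated to give 40% in this assay, with a range from 20% to 62%, pending the measurement.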

Compound 3, a percentage reported as inhibition, at one concentration (the size of the read-out at that concentration, not a potency): 37.8%
Compound 3: the middle estimate sits 2.2 percentage points above what was measured; the measured number falls inside the stated range.
By their numbers in this assay, from the lowest: compound 2; then compound 3; then compound 1.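

Methoxycarbonyl in place of nitro on this aromatic carbon gives a number 11 percentage points higher from compound 2 to compound 3 (beyond the scatter) in this assay and thus shows that a second group with the same count of hydrogen-bond acceptors as nitro does not give the same number. Methoxycarbonyl in place of chloro gives a number 19.9 percentage points lower from compound 1 to compound 3 (beyond the scatter) and leaves compound 1 the highest of the three, so this position now separates three groups into three distinct levels of inhibition at the tested concentration. No measurement at hand accounts for this order.

Still open, on these data alone, is how an amine, a carboxylic acid or a simple methyl at this same aromatic carbon would read against chloro. Also open, as far as these compounds go, is whether bromo or fluoro would stay near compound 1 or fall towards compound 3.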